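A few compounds are considered here, and "the series" means these few. Any claim that something is new, unique, unknown or untested is made for them only; others in the source may bear on it.

Measured compounds:
Compound 1, `O=C1C(=O)N(Cc2cn(CC(=O)N3CCNCC3)nn2)c2c(Cl)ccc(Cl)c21`, in a functional assay on MGC-803 cells (Homo sapiens) for inhibition, read by CCK-8 assay, with a stated time of 72 h (on this read-out higher numbers stand for weaker inhibition and lower numbers for stronger inhibition), compound 1 gives "nd(insoluble)" (no result reported), that is no result, being insoluble.
Compound 2, `O=C(Cn1cc(CN2C(=O)C(=O)c3c(Cl)ccc(Cl)c32)nn1)Nc1ccccc1`, in this assay compound 2 gives 17500 nM.
Compound 3, `CC(C)(C)OC(=O)N1CCN(C(=O)Cn2cc(CN3C(=O)C(=O)c4c(Cl)ccc(Cl)c43)nn2)CC1`, in this assay compound 3 gives 22000 nM.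

Compound 2 thus has the lowest of the two numbers reported, with compound 3 close by and within the usual scatter, so the two cannot be ordered. Compound 4, `O=C1C(=O)N(Cc2cn(CC(=O)N3CCCC3)nn2)c2c(Cl)ccc(Cl)c21`, is not yet measured. It differs from compound 2 in one place: pyrrolidin-1-yl in place of anilino on a carbonyl carbon. Among the measured compounds shown here, no measured pair shows what this change does, so the expected step from compound 2 is a small one, in no clear direction and not beyond the scatter. The estimated step for compound 4 in this assay is a 1.1-fold higher number from compound 2 to compound 4 (0.06 log units; within the scatter). Compound 4 is expected to give about 20000 nM, in the range 8000 nM to 50000 nM.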

Compound 4, half-maximal inhibitory concentration: 14800 nM
Compound 4: middle estimate off by 1.4-fold (0.13 log units), on the high side; the measured number falls inside the stated range.
By their numbers in this assay, from the lowest: compounds 4, 2 and 3 (each within the scatter of the next).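

Putting pyrrolidin-1-yl in place of anilino on this carbonyl carbon gives, in this assay, a 1.2-fold lower number from compound 2 to compound 4 (0.07 log units; within the scatter). Thus, for this one pair, losing the six-membered aromatic ring and the amide hydrogen leaves no readable difference on this read-out. Nothing available bears on a cause for this result. Still open, going by these compounds, is whether any group on this carbonyl carbon can carry the number beyond the scatter. A morpholin-4-yl group or a chain ending in a carboxylic acid would test this.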